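The source may report more compounds than this note shows. Statements on the series, on what has been measured and on what is new or still open speak of the compounds shown alone.

In a functional assay on SK-OV-3 cells (Homo sapiens) for cytotoxicity, read by spectrophotometry, with a stated time of 72 h (a lower number here means a stronger inhibitor, a higher number a weaker inhibitor), compound 1 `COc1ccc(-c2cccc(=O)n2-c2cc(OC)c(OC)c(OC)c2)cc1C` gives 583 nM while compound 2 `COc1ccc(-n2c(-c3cc(OC)c(OC)c(OC)c3)cccc2=O)cc1OCc1ccccc1` gives 25500 nM as the higher of the two numbers, a gap beyond the scatter. Compound 3 `COc1ccc(-n2c(-c3cc(OC)c(OC)c(OC)c3)cccc2=O)cc1O` has not yet been measured. Compared with compound 2 it carries hydrogen in place of benzyl on an oxygen on an aromatic ring and so turns benzyloxy to hydroxy. Among the measured compounds shown here, no measured step shows this change. For the measured compounds named here, compound 1 carries no benzyl and stands at 583 nM as the only guide. A large step to a lower number is expected in this assay with a 51-fold lower number from compound 2 to compound 3 (1.71 log units; beyond the scatter) as the estimate. For compound 3 the estimated value is 500 nM within an expected range from 50 nM to 5000 nM once measured.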

Compound 3, half-maximal inhibitory concentration: 1220 nM
Compound 3: middle estimate off by 2.4-fold (0.39 log units), on the low side; low and high end bracket the measured number.
By their numbers in this assay, from the lowest: compound 1; then compound 3; then compound 2.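

In this assay the change from benzyloxy to hydroxy on the aromatic ring gives the first step read at this position (a 21-fold lower number from compound 2 to compound 3 (1.32 log units; beyond the scatter)). It shows that this position responds strongly to the change, and that hydroxy gives the lower number of the two groups compared here. Nothing at hand explains the size of this step. Going by these compounds, whether an ethoxy group or a carboxymethoxy group on this oxygen would stay near hydroxy or move toward benzyloxy remains open, as does the effect of an amine in place of the hydroxy.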